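Carbonyl substituent notes: acetyl to propylcarbamoyl

This account rests on a few compounds, and the source may have more. Where it says the series, first, only, none or still open, it means among the compounds named here.

Measured so far in an assay on isolated protein for inhibition of steroid 17-alpha-hydroxylase/17,20 lyase (Homo sapiens); a lower number here means a stronger inhibitor, a higher number a weaker inhibitor:
compound 1 `CC(C)NC(=O)c1ccc2cc(C(O)(c3c[nH]cn3)C(C)C)ccc2c1`: 75 nM
compound 2 `CC(=O)c1ccc2cc(C(O)(c3c[nH]cn3)C(C)C)ccc2c1`: 28 nM

Within the data shown here, compound 2 holds the lowest number of the two; the only comparison, compound 1, shows a 2.7-fold lower number from compound 1 to compound 2 (0.43 log units; beyond the scatter). Compound 3 `CCCNC(=O)c1ccc2cc(C(O)(c3c[nH]cn3)C(C)C)ccc2c1` is the next step: propylamino in place of methyl on a carbonyl carbon. Among the measured compounds shown here, this reverses the one measured change, bringing back an amide with a propyl chain rather than an isopropyl one. The expectation is therefore a modest rise in this assay, a 2.1-fold higher number from compound 2 to compound 3 (0.33 log units; beyond the scatter), roughly undoing the measured drop. Estimate for compound 3: 60 nM, range 25 nM to 150 nM.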

Compound 3, half-maximal inhibitory concentration: 38 nM
For compound 3 the middle estimate is 1.6-fold (0.20 log units) above the measured one; low and high end bracket the measured number.
By their numbers in this assay, from the lowest: compounds 2, 3 and 1 (each within the scatter of the next, the first and the last beyond it).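

Acetyl to propylcarbamoyl on the carbonyl carbon stays within the scatter in this assay (a 1.4-fold higher number from compound 2 to compound 3 (0.13 log units; within the scatter)), so an amide at this position need not differ from acetyl, as the isopropyl amide of compound 1 did (a 2.7-fold lower number from compound 1 to compound 2 (0.43 log units; beyond the scatter)). Propyl in place of isopropyl on the amide-type nitrogen also stays within the scatter (a 2.0-fold lower number from compound 1 to compound 3 (0.30 log units; within the scatter)). No evidence bearing on a cause accompanies these steps.

Still open, on these data alone, is whether a butyl chain on the amide-type nitrogen would keep compound 3's level. As far as these compounds go, a hydroxyl on the carbonyl carbon, giving a carboxylic acid, is equally open.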